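This account rests on a few compounds, and the source may have more. Where it says the series, first, only, none or still open, it means among the compounds named here.

Measured compounds in a functional assay on WM 266-4 cells (Homo sapiens) for antiproliferative activity, read by MTT assay, with a stated time of 48 h; on this read-out higher numbers stand for weaker inhibition and lower numbers for stronger inhibition:

- compound 1, `Fc1ccc(C2=NN(c3nc(-c4ccc(Br)cc4)cs3)C(c3cccs3)C2)cc1`: compound 1 gives 220 nM
- compound 2, `Fc1ccc(C2=NN(c3nc(-c4ccccc4)cs3)C(c3cccs3)C2)cc1`: compound 2 gives 170 nM
- compound 3, `Clc1ccc(C2=NN(c3nc(-c4ccc(Br)cc4)cs3)C(c3cccs3)C2)cc1`: compound 3 gives 1450 nM

Compounds 1 and 2 share one core; compound 2 differs from compound 1 only in this: hydrogen in place of bromo on an aromatic carbon. On that change the number moved a 1.3-fold lower number from compound 1 to compound 2 (0.11 log units; within the scatter), so on this read-out compounds 1 and 2 cannot be told apart.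

Compound 3 carries a different core. Its difference from compound 1 is chloro in place of fluoro on an aromatic carbon, and with it the number moved a 6.6-fold higher number from compound 1 to compound 3 (0.82 log units; beyond the scatter). Compound 3 stands highest of the three measured numbers, and its steps to compound 1 and to compound 2 are both beyond the scatter.

Compound 4, `Clc1ccc(C2=NN(c3nc(-c4ccccc4)cs3)C(c3cccs3)C2)cc1`, has not yet been measured in this assay. It differs from compound 3 by hydrogen in place of bromo on an aromatic carbon. The place of this change is the same, word for word, as the place of the change from compound 1 to compound 2, so this is the same change, now made on the core of compound 3. It occurs twice among the compounds in hand, once measured.

The step from compound 3 to compound 4 is expected to be a 1.2-fold lower number from compound 3 to compound 4 (0.08 log units; within the scatter), set beside the earlier step from compound 1 to compound 2, and rests on that single earlier step a 1.3-fold lower number from compound 1 to compound 2 (0.11 log units; within the scatter). Whether the change transfers unaltered to the core of compound 3 is not tested by anything measured here, and the core difference itself moved the number beyond the scatter, so the range is kept wide.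

Compound 4 is estimated at 1200 nM, between 500 nM and 3000 nM.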

Compound 4, half-maximal inhibitory concentration: 2190 nM
For compound 4 the middle estimate is 1.8-fold (0.26 log units) below the measured one; low and high end bracket the measured number.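

In this assay the 4-bromophenyl to phenyl change reads as a 1.5-fold higher number from compound 3 to compound 4 (0.18 log units; within the scatter), so on the core of compound 3, as on the core of compound 1, its effect cannot be told from none, and the two readings agree: the same change on two cores in this assay, a 1.3-fold lower number (0.11 log units; within the scatter) from compound 1 to compound 2 and a 1.5-fold higher number (0.18 log units; within the scatter) from compound 3 to compound 4, 2.0-fold (0.29 log units) apart, within the scatter of two such steps

The chloro in place of fluoro change also carries over, with a 13-fold higher number from compound 2 to compound 4 (1.11 log units; beyond the scatter), and it lies beyond the scatter on both cores, with the two readings again in agreement: the same change on two cores in this assay, a 6.6-fold higher number (0.82 log units; beyond the scatter) from compound 1 to compound 3 and a 13-fold higher number (1.11 log units; beyond the scatter) from compound 2 to compound 4, 2.0-fold (0.29 log units) apart, within the scatter of two such steps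

These agreements rest on a single square of four compounds, so they show that the two changes behaved independently here, but they do not show that either change would carry to any other core in the series, and they give no reason for the higher numbers of the chloro compounds.

The compounds shown leave open how other groups would read in place of the bromo on the same aromatic carbon, such as a methoxy group, an amine or a carboxylic acid. They also leave open whether hydrogen, methyl or trifluoromethyl in place of the fluoro or chloro would follow the same step on both cores.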